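The compounds below may be only part of what the source reports. "The series", "measured", "known", "first", "only" and "open" are said of these compounds alone.

Measured in an assay on HEK293 cells for displacement of a labelled ligand from 5-hydroxytryptamine receptor 7 (Homo sapiens), with a stated time of 1 h; a higher number here means a weaker inhibitor, a lower number a stronger inhibitor:
compound 1 `CSc1ccccc1N1CCN(CCCCC(=O)N2CCC[C@H]2C(N)=O)CC1` — 163 nM
compound 2 `NC(=O)[C@@H]1CCCN1C(=O)CCCCCN1CCN(c2cccc(Cl)c2Cl)CC1` — 179 nM
compound 3 `COc1ccccc1N1CCN(CCCCC(=O)N2Cc3ccccc3C[C@H]2C(N)=O)CC1` — 551 nM

Compound 3 gives the highest number of the three. Compound 2 and compound 1 both sit below it, and each of those gaps lies beyond the usual scatter, so on the numbers shown compound 3 is the weakest of the measured set in this assay. Compound 1 and compound 2 lie within the scatter of one another and are not ranked against each other.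

Compound 4 `NC(=O)[C@@H]1Cc2ccccc2CN1C(=O)CCCCN1CCN(c2ccc(F)cc2)CC1` has not been measured. It keeps the core of compound 3 and differs in one place: 4-fluorophenyl in place of 2-methoxyphenyl on an amine nitrogen in a ring. Within the data shown here, no measured pair in this set shows that exchange, so the direction and size of the step cannot be read from a recorded step; it has to be estimated from the neighbourhood alone. Among the measured compounds shown here, with no measured step to lean on, a modest move toward a higher number is expected, not beyond what a single exchange on that ring would usually bring, and a wide range is kept. The step from compound 3 to compound 4 is estimated at a 1.6-fold higher number from compound 3 to compound 4 (0.21 log units; within the scatter). Compound 4 is thus expected to give about 900 nM in this assay, within roughly 300 nM to 2700 nM.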

Compound 4, inhibition constant: 295 nM
Compound 4: middle estimate off by 3.1-fold (0.48 log units), on the high side; the measured number lies below the stated range.
By their numbers in this assay, from the lowest: compounds 1, 2, 4 and 3 (each within the scatter of the next, the first and the last beyond it).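

Among these compounds, the step at this position, a 1.9-fold lower number from compound 3 to compound 4 (0.27 log units; within the scatter), is the first recorded exchange on the amine nitrogen of the six-membered ring with two nitrogens, and it is measured in this assay on the core of compound 3. 2-Methoxyphenyl, which carries a hydrogen-bond acceptor, gives way to 4-fluorophenyl, which carries none, and on this core the pair cannot be told apart, so the oxygen of the leaving group is not required for a value in this range. Nothing measured here bears on the reason for this outcome.

The exchange alters both the substituent and its place on the phenyl ring, so this single pair cannot separate the two, and a plain phenyl group or a pyridine ring on the same nitrogen would be needed to show whether any substituent matters there. From the compounds shown here alone, whether 4-fluorophenyl and 2-methoxyphenyl also remain indistinguishable on the core of compound 1, or with a longer chain on the core of compound 3, stays open.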